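Swapping an aryl group for a pyridine: expecting a modest shift

The source may hold more compounds than are shown below. What is called first, only, known or untested is meant among the compounds shown, and "the series" means these compounds.

Measured so far:
- Compound 1 `COc1ccc(S(=O)(=O)N2CCc3cccc(-c4ccc(F)nc4)c32)cc1`: 143 nM
- Compound 2 `COc1ccc(-c2cccc3c2N(S(=O)(=O)c2ccc(OC)cc2)CC3)cc1`: 337 nM

In a functional assay on KB cells (Homo sapiens) for inhibition, with a stated time of 72 h (on this read-out lower numbers stand for stronger inhibition and higher numbers for weaker inhibition), compound 2 gives 337 nM, the higher of the two numbers and so the weaker inhibition. Compound 3 `COc1ccc(S(=O)(=O)N2CCc3cccc(-c4ccncc4)c32)cc1` has not yet been measured. It differs from compound 2 by pyridin-4-yl in place of 4-methoxyphenyl on an aromatic carbon, with pyridin-4-yl in place of 4-methoxyphenyl on an aromatic carbon.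

For the measured compounds named here, only one measured step bears on this change: a 2.4-fold higher number from compound 1 to compound 2 (0.37 log units; beyond the scatter). That step put 4-methoxyphenyl in place of 6-fluoropyridin-3-yl, so the compound with the pyridine ring holds the lower number. Pyridin-4-yl is a different group, and a single pair is thin evidence. A modest move to a lower number in this assay is therefore expected, of about the same size. The expected change is a 2.0-fold lower number from compound 2 to compound 3 (0.30 log units; within the scatter). For compound 3 the estimated value is 170 nM, with an expected range of 65 nM to 420 nM.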

Compound 3, half-maximal inhibitory concentration: 96 nM
The estimate for compound 3 lay 1.8-fold (0.25 log units) above the measured number; the measured number falls inside the stated range.
By their numbers in this assay, from the lowest: compounds 3 and 1 (each within the scatter of the next); then compound 2.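

In this assay the earlier pair held only one pyridine against 4-methoxyphenyl, and now a second pyridine, pyridin-4-yl, also gives a lower number on this aromatic carbon, with a 3.5-fold lower number from compound 2 to compound 3 (0.55 log units; beyond the scatter) as the step. The two pyridines do not separate: a 1.5-fold lower number from compound 1 to compound 3 (0.17 log units; within the scatter) is the step between them, so pyridin-4-yl and 6-fluoropyridin-3-yl read alike here. Nothing available gives a reason for these results.

Only one carbon-only aromatic ring, 4-methoxyphenyl, stands against the two pyridines, so the compounds shown cannot separate the effect of the ring nitrogen from that of the methoxy group. As far as these compounds go, it also stays open how a plain phenyl ring would read on this carbon, or an amine or a carboxylic acid in place of the ring.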